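Series notes: heteroaryl ether change from compound 3 to compound 4

This account rests on a few compounds, and the source may have more. Where it says the series, first, only, none or still open, it means among the compounds named here.

The series keeps one core and varies the ring on the saturated chain carbon bound to an oxygen on an aromatic ring. In an assay on CHO cells for displacement of a labelled ligand from melanin-concentrating hormone receptor 1 (Homo sapiens), read by scintillation counting, with a stated time of 1 h (a higher number here means a weaker inhibitor, a lower number a stronger inhibitor), compound 1 `Cn1c(C2CC2)nc2ccc(-n3ccc(OCc4ccc(Cl)cc4)cc3=O)cc21` gives 35 nM. Compound 2 `Cn1c(C2CC2)nc2ccc(-n3ccc(OCc4cccc(Cl)c4)cc3=O)cc21` gives 100 nM in this assay, a step of a 2.9-fold higher number from compound 1 to compound 2 (0.46 log units; beyond the scatter). Compound 3 `Cn1c(C2CC2)nc2ccc(-n3ccc(OCc4ncc(Cl)cn4)cc3=O)cc21` reaches only the limit of this assay, reported as > 1000 nM. Compound 3 thus stands at the limit of > 1000 nM in this assay, at which 1 of the 3 values shown sits, and the steps of an at least 28-fold higher number from compound 1 to compound 3 (1.45 log units; beyond the scatter) and an at least 10-fold higher number from compound 2 to compound 3 (1.00 log units; beyond the scatter) both mark a weaker inhibitor.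

Compound 4 `Cn1c(C2CC2)nc2ccc(-n3ccc(OCc4csc(Cl)c4)cc3=O)cc21` is not yet measured. The change is 5-chlorothiophen-3-yl in place of 5-chloropyrimidin-2-yl on a saturated chain carbon bound to an oxygen on an aromatic ring. For the measured compounds named here, the steps that bear on it are an at least 28-fold higher number from compound 1 to compound 3 (1.45 log units; beyond the scatter) and an at least 10-fold higher number from compound 2 to compound 3 (1.00 log units; beyond the scatter), both losses when the 5-chloropyrimidin-2-yl entered; compound 4 moves away from that group toward the rings that gave numbers. The expected step is a lower number, an at least 5.0-fold lower number from compound 3 to compound 4 (0.69 log units; beyond the scatter), without full recovery to the level of compound 1. Compound 4 is expected to give about 200 nM in this assay, between 50 nM and 800 nM.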

Compound 4, half-maximal inhibitory concentration: 14 nM
Compound 4: middle estimate off by 14-fold (1.15 log units), on the high side; measured number below the stated range.
By their numbers in this assay, from the lowest: compound 4; then compound 1; then compound 2. At a limit, above all of these: compound 3.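

At the saturated chain carbon bound to an oxygen on an aromatic ring, a heteroaryl ring is not in itself a loss in this assay: 5-chlorothiophen-3-yl in place of 5-chloropyrimidin-2-yl gives an at least 71-fold lower number from compound 3 to compound 4 (1.85 log units; beyond the scatter). Compound 3 is held only at a limit: the limit of > 1000 nM in this assay, at which 1 of the 4 values shown sits. The thiophene also goes past both chlorophenyl rings, with a 7.1-fold lower number from compound 2 to compound 4 (0.85 log units; beyond the scatter) and a 2.5-fold lower number from compound 1 to compound 4 (0.40 log units; beyond the scatter), so among the compounds shown a phenyl ring is not required at this place.

Compound 4 differs from compound 3 in ring size and in its hetero atoms at once, and the compounds shown do not separate these two changes. Also open, going by these compounds, is whether the chlorine matters on the thiophene, as a plain thiophen-3-yl or a 5-methylthiophen-3-yl would show.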